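A few compounds are considered here, and "the series" means these few. Any claim that something is new, unique, unknown or untested is made for them only; others in the source may bear on it.

Working notes on the carbamate series.

Three carbamates sharing the core of compound 1 `N#Cc1ccc(F)c(OC(=O)N2CCC(C(c3ccccc3)c3ccccc3)CC2)c1` have been run in an assay on isolated protein for inhibition of Fatty-acid amide hydrolase 1 (Rattus norvegicus), read by fluorescence; a higher number here means a weaker inhibitor, a lower number a stronger inhibitor. In this assay compound 1 gives > 1000 nM, a limit of the assay rather than a number. Compound 2 `N#Cc1cccc(OC(=O)N2CCC(C(c3ccccc3)c3ccccc3)CC2)c1` gives in this assay > 1000 nM, again a limit. Compound 3 `COc1cc(C#N)cc(OC(=O)N2CCC(C(c3ccccc3)c3ccccc3)CC2)c1` gives in this assay > 1000 nM, also a limit. The steps a step that the two limits leave unreadable from compound 1 to compound 2, a step that the two limits leave unreadable from compound 1 to compound 3 and a step that the two limits leave unreadable from compound 2 to compound 3 are all unreadable because every end sits at the limit of > 1000 nM in this assay, at which 3 of the 3 values shown sit. Compound 3 thus stands only at a limit, as do the two other values shown; no ordering among the three is readable.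

Compound 4 `N#Cc1cccc(OC(=O)N2CCC(C(c3ccccc3)c3ccccc3)CC2)n1` is the next member to be measured in this assay. It differs from compound 3 by 6-cyanopyridin-2-yl in place of 3-cyano-5-methoxyphenyl on an oxygen next to a carbonyl group. Among the measured compounds shown here, none of the measured steps touches this change, and the unreadable steps give no size to carry over. The step that the limit leaves unreadable from compound 3 to compound 4 that the estimate means is expected to stay within the scatter. In this assay compound 4 is estimated at 1500 nM, in a range from 300 nM to 10000 nM.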

Compound 4, half-maximal inhibitory concentration: > 1000 nM
Compound 4: only a limit was reported; the forecaster's own chance of this, stated with the estimate: 60%; the middle value does not contradict the limit.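

Among the compounds shown here, no step to compound 4 from compound 1, compound 2 or compound 3 can be read in this assay, because all four compounds give only a limit: the limit of > 1000 nM in this assay, at which 4 of the 4 values shown sit.

The compounds shown leave open how strongly any of these four carbamates inhibits the enzyme, and whether 6-cyanopyridin-2-yl differs from the three aryl groups it replaces.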